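This account rests on a few compounds, and the source may have more. Where it says the series, first, only, none or still open, it means among the compounds named here.

Measured compounds:
compound 1, `COCC(C(=O)N1CCN(c2cccc(C(F)(F)F)c2)CC1)N1C(=O)CCC1=O`, 100%
compound 2, `CC(C(=O)N1CCN(c2ccccc2)CC1)N1C(=O)CCC1=O`, 50%
compound 3, `CCC(C(=O)N1CCN(c2cccc(F)c2)CC1)N1C(=O)CCC1=O`, 75%

In a functional assay on the whole organism (strain Swiss) with Mus musculus as the target, in the maximal electroshock model, with a stated time of 1 h, at a dose of 300 mg/kg by the intraperitoneal route (a higher number here means a stronger effect of the compound at the dose given, a lower number a weaker effect), compound 1 gives 100%, compound 2 gives 50% and compound 3 gives 75%. Compound 3 thus stands second of the three numbers, beyond the scatter from compound 1 above it and beyond the scatter from compound 2 below it.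

Compound 4, `CCC(C(=O)N1CCN(c2ccccc2F)CC1)N1C(=O)CCC1=O`, has not yet been measured. It differs from compound 3 in one place: 2-fluorophenyl in place of 3-fluorophenyl on an amine nitrogen in a ring. Among the measured compounds shown here, no pair of measured compounds shows a change of this kind, so nothing here tells the size of its effect. The change is expected to bring no step beyond the scatter in this assay, an estimated step of no change at the digits printed from compound 3 to compound 4 (within the scatter). Compound 4 is expected to give about 75% in this assay, within a range from 50% to 100%.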

Compound 4, a percentage reported as activity, at one dose (the size of the read-out at that dose, not a potency): 50%
Estimate against measurement, compound 4: 25 percentage points above; low and high end bracket the measured number.
By their numbers in this assay, from the lowest: compounds 2 and 4 (each within the scatter of the next); then compound 3; then compound 1.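

Moving the fluorine alone changes the read-out: 2-fluorophenyl in place of 3-fluorophenyl, with the same atoms, gives a number 25 percentage points lower from compound 3 to compound 4 (beyond the scatter) in this assay. The earlier compounds shown here could not show this, since none of them forms a pair differing only in where a group sits on the phenyl. No measured data at hand account for the step.

Still open, from the compounds shown here alone, is how a chlorine atom or a methoxy group would read in place of this fluorine. Also open, going by these compounds, is whether the same change gives a similar step with a longer chain on the succinimide-bearing carbon.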